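Pyridyl for phenyl on the saturated ring carbon

The source may report more compounds than this note shows. Statements on the series, on what has been measured and on what is new or still open speak of the compounds shown alone.

Compound 1 `Cc1cccc(NC(=O)CN2CCC(c3ccccc3)CC2)c1` is the reference of the set. Within the data shown here, in an assay on HEK293 cells for displacement of a labelled ligand from D(4) dopamine receptor (Homo sapiens), read by scintillation counting, with a stated time of 90 min (a higher number here means a weaker inhibitor, a lower number a stronger inhibitor), compound 1 gives 1.4 nM, the lowest of the three numbers measured so far. Compound 2 `Cc1cccc(NC(=O)CCN2CCN(c3ncccn3)CC2)c1` gives 33 nM in this assay, a higher number than compound 1 by more than the scatter. Compound 3 `Cc1cccc(NC(=O)CCN2CCC(c3ccccn3)CC2)c1` gives 76.4 nM in this assay, the highest number of the three and again beyond the scatter from compound 1. Among the measured compounds shown here, neither compound 2 nor compound 3 differs from compound 1 in a single place, so only the values themselves can be set side by side; no single-change step is available.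

Compound 4 `Cc1ccc(C2CCN(CC(=O)Nc3cccc(C)c3)CC2)nc1` is the next compound for this assay. Relative to compound 1 the change is 5-methylpyridin-2-yl in place of phenyl on a saturated ring carbon. For the measured compounds named here, no measured pair shows this kind of change, so its size must be guessed. The expectation is a rise in the number for compound 4 that exceeds the scatter, but a modest one, since compound 1 sits far below the other two values and the core is otherwise unchanged. The expected step is a 5.7-fold higher number from compound 1 to compound 4 (0.76 log units; beyond the scatter). For compound 4 the estimate in this assay is 8 nM, with a range from 2 nM to 35 nM.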

Compound 4, inhibition constant: 6.87 nM
Beside the measured number, compound 4's estimate is 1.2-fold (0.07 log units) above it; low and high end bracket the measured number.
By their numbers in this assay, from the lowest: compound 1; then compound 4; then compound 2; then compound 3.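

In this assay, the series now has its first single-change step: 5-methylpyridin-2-yl in place of phenyl on a saturated ring carbon gives a 4.9-fold higher number from compound 1 to compound 4 (0.69 log units; beyond the scatter), a modest step that lies beyond the scatter. This position therefore tolerates the replacement of an all-carbon aromatic ring by one with a ring nitrogen and an added methyl, at a limited cost, with compound 4 still at 6.87 nM. No measurement bearing on the reason for this step is available here.

The step carries two differences at once, the ring nitrogen and the methyl, and the compounds shown do not divide it between them; on the core of compound 1, a plain pyridin-2-yl group and a methyl-bearing phenyl group would separate the two. Also open, going by these compounds, is how far this position tolerates other groups on the pyridine ring, such as a methoxy group or a chlorine atom in place of the methyl, and whether the step would keep its size on a longer chain.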